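Benzotriazine dioxide amines: amine swap on tert-butyl core

The source may hold more compounds than are shown below. What is called first, only, known or untested is meant among the compounds shown, and "the series" means these compounds.

Measured compounds so far:
compound 1, `CCN(CC)CCNc1n[n+]([O-])c2ccc(C(C)C)cc2[n+]1[O-]`, 800 nM
compound 2, `CC(C)c1ccc2c(c1)[n+]([O-])c(NCCN1CCCCC1)n[n+]2[O-]`, 1100 nM
compound 3, `CCN(CC)CCNc1n[n+]([O-])c2ccc(C(C)(C)C)cc2[n+]1[O-]`, 900 nM

All three were run in a functional assay on SiHa cells (Homo sapiens) for cytotoxicity, with a stated time of 4 h; on this read-out lower numbers stand for stronger inhibition and higher numbers for weaker inhibition. Compound 1 gives 800 nM. Compound 2 differs from compound 1 by the change (piperidin-1-yl in place of diethylamino on a saturated chain carbon, two bonds along the chain from a nitrogen on an aromatic ring), and the step is a 1.4-fold higher number from compound 1 to compound 2 (0.14 log units; within the scatter). Compound 3 differs from compound 1 by the change (methyl in place of hydrogen on a saturated chain carbon bound to an aromatic carbon and two saturated chain carbons), with the step of a 1.1-fold higher number from compound 1 to compound 3 (0.05 log units; within the scatter). Neither step leaves the scatter, so the three measured values are read as a flat set.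

Compound 4, `CC(C)(C)c1ccc2c(c1)[n+]([O-])c(NCCN1CCCCC1)n[n+]2[O-]`, is not yet measured. It carries the core of compound 3 and differs from it by piperidin-1-yl in place of diethylamino on a saturated chain carbon, two bonds along the chain from a nitrogen on an aromatic ring. This is the same change as that from compound 1 to compound 2: the two place descriptions are identical word for word, and only the cores differ, as given for compound 1 against compound 3. The change occurs twice among the compounds shown, once measured and once not.

Within the data shown here, the expectation for compound 4 rests on the single measured instance of this change, because a 1.4-fold higher number from compound 1 to compound 2 (0.14 log units; within the scatter) stayed within the scatter, and on compound 3 as the starting point, because 900 nM itself sits within the scatter of compound 1. The step from compound 3 to compound 4 is therefore expected to be a 1.3-fold higher number from compound 3 to compound 4 (0.12 log units; within the scatter), about the size of the earlier one. For compound 4 in this assay the estimate is 1200 nM, with a range from 600 nM to 2500 nM that allows for the usual scatter in either direction.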

Compound 4, half-maximal inhibitory concentration: 600 nM
The estimate for compound 4 lay 2.0-fold (0.30 log units) above the measured number; measured number inside the range.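

In this assay, piperidin-1-yl in place of diethylamino on the core of compound 3 gives a 1.5-fold lower number from compound 3 to compound 4 (0.18 log units; within the scatter), and this step does not separate from the same change on the core of compound 1: the same change on two cores in this assay, a 1.4-fold higher number (0.14 log units; within the scatter) from compound 1 to compound 2 and a 1.5-fold lower number (0.18 log units; within the scatter) from compound 3 to compound 4, 2.1-fold (0.31 log units) apart, within the scatter of two such steps

Methyl in place of hydrogen, read with the 2-(piperidin-1-yl)ethyl chain in place, gives a 1.8-fold lower number from compound 2 to compound 4 (0.26 log units; within the scatter), and this step likewise does not separate from its counterpart with the 2-(diethylamino)ethyl chain: the same change on two cores in this assay, a 1.1-fold higher number (0.05 log units; within the scatter) from compound 1 to compound 3 and a 1.8-fold lower number (0.26 log units; within the scatter) from compound 2 to compound 4, 2.1-fold (0.31 log units) apart, within the scatter of two such steps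

The four compounds therefore show no dependence on the core that the scatter can resolve for either change, but they do not show that either change has a real effect or a fixed direction, and one pair of steps per change cannot establish that a change carries across this series in general.

Going by these compounds, it remains open whether the flat picture would hold with a different amine on the chain, such as morpholine or pyrrolidine, or with a longer chain between the two nitrogens. It is equally open whether it would survive a different group on the core, such as trifluoromethyl or methoxy, in place of the branched alkyl groups shown.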